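Compound 3: exchanging the group on the carbonyl carbon

The source may hold more compounds than are shown below. What is called first, only, known or untested is meant among the compounds shown, and "the series" means these compounds.

In a physicochemical assay for solubility (on this read-out higher numbers stand for higher solubility and lower numbers for lower solubility), compound 1 `O=S(=O)(NC1CCN(S(=O)(=O)c2ccccc2)CC1)c1cc(S(=O)(=O)c2ccccc2)ccc1C(F)(F)F` gives 25000 nM. Compound 2 `CC(C)(C)OC(=O)N1CCC[C@H]1C(=O)N1CCC(NS(=O)(=O)c2cc(S(=O)(=O)c3ccccc3)ccc2C(F)(F)F)CC1` gives 25000 nM, level with compound 1 within the scatter. Compound 3 `O=C(CC1CCNCC1)N1CCC(NS(=O)(=O)c2cc(S(=O)(=O)c3ccccc3)ccc2C(F)(F)F)CC1`, not yet measured, has (piperidin-4-yl)methyl in place of 1-(tert-butoxycarbonyl)pyrrolidin-2-yl on a carbonyl carbon. Going by the values given here, no measured single-place step is available to size this change. Among the compounds with values here, the only guide is the level reading of compound 2 at 25000 nM, so no shift beyond the scatter is expected in this assay. The expected step is no change at the digits printed from compound 2 to compound 3 (within the scatter). For compound 3 the estimated value is 25000 nM, with an expected range of 12000 nM to 35000 nM.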

Compound 3, solubility: 100000 nM
For compound 3 the middle estimate is 4.0-fold (0.60 log units) below the measured one, and the stated range ends below it.
By their numbers in this assay, from the lowest: compounds 1 and 2 (each within the scatter of the next); then compound 3.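

In this assay, going by these compounds alone, the group on the carbonyl carbon is the first change to move the read-out beyond the scatter: a 4.0-fold higher number from compound 2 to compound 3 (0.60 log units; beyond the scatter). Compound 1 and compound 2 had read level despite their different groups on the amine nitrogen in a ring, whereas ((piperidin-4-yl)methyl)carbonyl in place of phenylsulfonyl gives a 4.0-fold higher number from compound 1 to compound 3 (0.60 log units; beyond the scatter). No measurement here ties these steps to any property of the entering group.

Which part of (piperidin-4-yl)methyl carries the step remains open. So does whether an open-chain amine or a carboxylic acid on the carbonyl carbon would give a step of similar size.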